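Two Hydroxyphenyl Isomers on a Shared Double-Bonded Nitrogen

The source may hold more compounds than are shown below. What is called first, only, known or untested is meant among the compounds shown, and "the series" means these compounds.

Compound 1, `O=c1cc(/C=N\c2ccccc2O)c2c(OCc3ccccc3)cc(OCc3ccccc3)cc2o1`: 7760 nM
Compound 2, `O=c1cc(/C=N\Nc2ccccc2)c2ccc(OCc3ccccc3)cc2o1`: 13200 nM

Of the compounds shown here, two have been measured in a functional assay, read by spectrophotometry, with a stated time of 3 min; on this read-out lower numbers stand for stronger inhibition and higher numbers for weaker inhibition. Compound 1 gives 7760 nM, and compound 2 gives 13200 nM; the two numbers lie within the usual scatter of each other, so neither can be called the more potent of the pair. Among the measured compounds shown here, no step between two measured compounds that differ in a single place is available, so the only guide to the next compound is the two values themselves.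

Compound 3, `O=c1cc(/C=N\c2ccc(O)cc2)c2c(OCc3ccccc3)cc(OCc3ccccc3)cc2o1`, differs from compound 1 in one place: 4-hydroxyphenyl in place of 2-hydroxyphenyl on a double-bonded nitrogen. In the absence of any measured step of this kind, the change from compound 1 to compound 3 is expected to give a step of a 1.0-fold higher number from compound 1 to compound 3 (0.01 log units; within the scatter) in this assay, that is, none beyond the scatter. Compound 3 is therefore estimated at 8000 nM, with a range from 2500 nM to 25000 nM.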

Compound 3, half-maximal inhibitory concentration: 3570 nM
For compound 3 the middle estimate is 2.2-fold (0.35 log units) above the measured one, within the range that was stated.
By their numbers in this assay, from the lowest: compound 3; then compounds 1 and 2 (each within the scatter of the next).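

In this assay, among the compounds shown here, 4-hydroxyphenyl in place of 2-hydroxyphenyl on a double-bonded nitrogen gives a 2.2-fold lower number from compound 1 to compound 3 (0.34 log units; beyond the scatter), the first step between compounds that differ in one place. The two groups have the same atoms, joined differently, so this position tells two isomers apart even though what is counted for each group is the same. Nothing measured here accounts for the step.

The compounds shown leave open whether the hydroxyl itself matters on this ring, which a plain phenyl, a methoxy group or an amine in its place would help to settle. They also leave open whether the same step would appear with the core of compound 2, which carries a different link to its phenyl ring.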